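This account rests on a few compounds, and the source may have more. Where it says the series, first, only, none or still open, it means among the compounds named here.

Working notes on the series. Three members have been measured in a functional assay on HCC1806 cells (Homo sapiens) for inhibition, read by sulforhodamine B assay, tested at 10 uM; on this read-out higher numbers stand for more inhibition at the one concentration tested (going by the name of the read-out) and lower numbers for less inhibition. Compound 1 `CN1CCN(c2ccc(C3=NN(C(=O)CCCl)C(c4ccc(N(C)C)cc4)C3)cc2)CC1` gives 1.7%. Compound 2 `CN1CCN(c2ccc(C3=NN(C(=O)c4ccc(C(F)(F)F)cc4)C(c4ccc(N(C)C)cc4)C3)cc2)CC1` gives 84.1%, and compound 3 `CN1CCN(c2ccc(C3=NN(S(C)(=O)=O)C(c4ccc(N(C)C)cc4)C3)cc2)CC1` gives -18.5%. Compound 3 therefore stands lowest of the three in this assay, with compound 1 nearest to it and compound 2 furthest away. Among the steps between these members, a number 82.4 percentage points higher from compound 1 to compound 2 (beyond the scatter), a number 20.2 percentage points lower from compound 1 to compound 3 (beyond the scatter) and a number 102.6 percentage points lower from compound 2 to compound 3 (beyond the scatter).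

The next member is compound 4 `CN1CCN(c2ccc(C3=NN(S(=O)(=O)c4ccc(F)cc4)C(c4ccc(N(C)C)cc4)C3)cc2)CC1`, which differs from compound 3 by one change: 4-fluorophenyl in place of methyl on a sulfonyl sulfur. Among the compounds with values here, no measured step exchanges methyl for 4-fluorophenyl on a sulfonyl sulfur. The nearest parallel is the step from compound 1 to compound 2, where 2-chloroethyl on a carbonyl carbon gave way to 4-(trifluoromethyl)phenyl and a number 82.4 percentage points higher from compound 1 to compound 2 (beyond the scatter) followed; the step from compound 2 to compound 3 likewise places the aryl-bearing member far above the methylsulfonyl member. On that basis a rise beyond the scatter is expected for compound 4, with the expected step of a number 58.5 percentage points higher from compound 3 to compound 4 (beyond the scatter). Within the data shown here, the size is the uncertain part: the change sits on a sulfonyl sulfur rather than a carbonyl carbon, and no measured pair covers that. Compound 4 is estimated at 40% in this assay, with a range from 0% to 80%.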

Compound 4, a percentage reported as inhibition, at one concentration (the size of the read-out at that concentration, not a potency): 92.3%
For compound 4 the middle estimate is 52.3 percentage points below the measured one, and the stated range ends below it.
By their numbers in this assay, from the lowest: compound 3; then compound 1; then compounds 2 and 4 (each within the scatter of the next).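

On a sulfonyl sulfur whose other neighbour is the sulfonamide nitrogen in a ring, the exchange of methyl for 4-fluorophenyl gives a number 110.8 percentage points higher from compound 3 to compound 4 (beyond the scatter) in this assay, so this position is not tied to the low number of compound 3 and a sulfonyl member can sit at the top of the series. Within the data shown here, the (4-fluorophenyl)sulfonyl group stands level with (4-(trifluoromethyl)phenyl)carbonyl, with a number 8.2 percentage points higher from compound 2 to compound 4 (within the scatter), while against (2-chloroethyl)carbonyl it gives a number 90.6 percentage points higher from compound 1 to compound 4 (beyond the scatter); across these four compounds the two aryl-bearing members stand high and the two without an aryl ring stand low, with no member going against this. No measurement here bears on why the aryl ring carries so much weight at this position.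

Compounds 2 and 4 differ in both the linking group and the ring substituent, so the separate contributions of sulfonyl against carbonyl and of fluoro against trifluoromethyl stay unresolved. The compounds shown also leave open whether an unsubstituted phenyl, a benzyl group, a longer alkyl chain or a pyridine ring on the sulfonyl sulfur would keep the high number of compound 4.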